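The source may report more compounds than this note shows. Statements on the series, on what has been measured and on what is new or still open speak of the compounds shown alone.

Three compounds share one core and differ in a single group attached to it. Compound 1 `Brc1cn2ccnc2c(-c2ccc3ncn(C4CCCCC4)c3c2)n1` carries bromo on an aromatic carbon; compound 2 `c1ccc(-c2cn3ccnc3c(-c3ccc4ncn(C5CCCCC5)c4c3)n2)cc1` carries phenyl there; compound 3 `COc1ccccc1-c1cn2ccnc2c(-c2ccc3ncn(C4CCCCC4)c3c2)n1` carries 2-methoxyphenyl. In a functional assay on SR cells (Homo sapiens) for inhibition, read by sulforhodamine B assay, with a stated time of 48 h, tested at 10 uM (a higher number here means more inhibition at the concentration tested (going by the name of the read-out), a lower number less inhibition), compound 1 gives 26.8%, compound 2 gives 59.8%, and compound 3 gives 26.3%. Compound 3 thus stands lowest of the three, though the gap to compound 1 lies within the scatter, while the step of a number 33.5 percentage points lower from compound 2 to compound 3 (beyond the scatter) is large and beyond it.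

Compound 4 `c1csc(-c2cn3ccnc3c(-c3ccc4ncn(C5CCCCC5)c4c3)n2)c1` has not yet been measured in this assay. The change from compound 3 is thiophen-2-yl in place of 2-methoxyphenyl on an aromatic carbon.

Going by the values given here, three measured steps bear on this. The step of a number 33 percentage points higher from compound 1 to compound 2 (beyond the scatter) shows that an unsubstituted aromatic ring in this position gives a large rise over bromo. The step of a number 0.5 percentage points lower from compound 1 to compound 3 (within the scatter) shows that 2-methoxyphenyl gives no such rise, and the step of a number 33.5 percentage points lower from compound 2 to compound 3 (beyond the scatter) shows that methoxy on that ring removes the whole gain. Thiophen-2-yl brings in an aromatic ring without methoxy, so the closer match is compound 2, and a rise from compound 3 is expected, by roughly a number 21.7 percentage points higher from compound 3 to compound 4 (beyond the scatter). For compound 4 the expected value in this assay is 48%, with a range from 25% to 68%.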

Compound 4, a percentage reported as inhibition, at one concentration (the size of the read-out at that concentration, not a potency): 27.2%
For compound 4 the middle estimate is 20.8 percentage points above the measured one; the range from low to high includes it.
By their numbers in this assay, from the lowest: compounds 3, 1 and 4 (each within the scatter of the next); then compound 2.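

In this assay, the step of a number 32.6 percentage points lower from compound 2 to compound 4 (beyond the scatter) shows that the gain seen with phenyl does not extend to thiophen-2-yl, so an aromatic ring without methoxy at this position is not enough to produce it. With the steps of a number 0.4 percentage points higher from compound 1 to compound 4 (within the scatter) and a number 0.9 percentage points higher from compound 3 to compound 4 (within the scatter), thiophen-2-yl, bromo and 2-methoxyphenyl cannot be told apart in this read-out, and among the four groups compared here, phenyl in compound 2 alone stands apart. Nothing available here accounts for this difference between phenyl and thiophen-2-yl.

The compounds shown leave open whether the gain belongs to phenyl alone or also appears with another six-membered aromatic ring, such as pyridin-3-yl, and whether a phenyl ring carrying a group other than methoxy, such as fluoro or an amine, keeps it. They also leave open how these groups would compare across a range of concentrations, since a reading at a single concentration gives the size of the inhibition and not a potency.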